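This account rests on a few compounds, and the source may have more. Where it says the series, first, only, none or still open, it means among the compounds named here.

Compound 3 `CN1CCN(c2ccc(Nc3ncc4nc(Nc5ccc(F)cc5)n(CCNS(=O)(=O)C5CC5)c4n3)cc2)CC1` gives, in a functional assay on HCC827 cells (Homo sapiens) for antiproliferative activity, read by MTT assay, with a stated time of 72 h (a lower number here means a stronger inhibitor, a higher number a weaker inhibitor), a reading of 50 nM, which places it second highest of the three numbers in hand: compound 2 `CN1CCN(c2ccc(Nc3ncc4nc(Nc5ccc(F)cc5)n([C@@H]5CCCNC5)c4n3)cc2)CC1` gives 120 nM, and compound 1 `CN1CCN(c2ccc(Nc3ncc4nc(Nc5ccc(F)cc5)n([C@H]5CCCN(C(=O)CO)C5)c4n3)cc2)CC1` gives 1.8 nM. Compound 4 `CN1CCN(c2ccc(Nc3ncc4nc(Nc5ccc(F)cc5)n([C@@H]5CCCN(C(=O)CO)C5)c4n3)cc2)CC1` is not yet measured; it differs from compound 3 by 1-((hydroxymethyl)carbonyl)piperidin-3-yl in place of 2-((cyclopropylsulfonyl)amino)ethyl on an aromatic nitrogen. Going by the values given here, two measured steps bear on this change. The step of a 28-fold higher number from compound 1 to compound 3 (1.44 log units; beyond the scatter) runs in the opposite direction to the one now taken, and the step of a 2.4-fold lower number from compound 2 to compound 3 (0.38 log units; beyond the scatter) shows that the 2-((cyclopropylsulfonyl)amino)ethyl group sits modestly below a bare piperidin-3-yl. Among the compounds with values here, compound 1 carries the same 1-((hydroxymethyl)carbonyl)piperidin-3-yl group as compound 4, though the two structures differ at the defined stereocentre, for which no step is known. On that basis a large fall in this assay is expected for compound 4, tempered for the unknown effect of the stereocentre, amounting to an 8.3-fold lower number from compound 3 to compound 4 (0.92 log units; beyond the scatter). Compound 4 is therefore estimated at 6 nM, within a range from 1.5 nM to 40 nM.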

Compound 4, half-maximal inhibitory concentration: 66 nM
Beside the measured number, compound 4's estimate is 11-fold (1.04 log units) below it, outside the stated range (above it).
By their numbers in this assay, from the lowest: compound 1; then compounds 3, 4 and 2 (each within the scatter of the next, the first and the last beyond it).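

In this assay, the 1-((hydroxymethyl)carbonyl)piperidin-3-yl group on the aromatic nitrogen does not by itself give the low number of compound 1, as the change of configuration alone shows (a 37-fold higher number from compound 1 to compound 4 (1.56 log units; beyond the scatter)). In the configuration of compound 4, this group is not separated from 2-((cyclopropylsulfonyl)amino)ethyl (a 1.3-fold higher number from compound 3 to compound 4 (0.12 log units; within the scatter)), and (hydroxymethyl)carbonyl on the ring amine nitrogen is not separated from hydrogen (a 1.8-fold lower number from compound 2 to compound 4 (0.26 log units; within the scatter)). The large step can be assigned to the stereocentre at a saturated ring carbon, drawn S in compound 1 and R in compound 4, because of this: the fact that compounds 1 and 4 differ only in the configuration as drawn.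

Still open, going by these compounds, is how a piperidin-3-yl with hydrogen on the ring amine nitrogen would read in the configuration of compound 1, and so what the (hydroxymethyl)carbonyl group adds there. Also open, on these data alone, is whether an acetyl or cyclopropylsulfonyl group on that nitrogen would keep the low number in that configuration.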